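Swapping 4-bromophenyl for 3,4-dimethoxyphenyl on an acetylated core

The source may hold more compounds than are shown below. What is called first, only, known or untested is meant among the compounds shown, and "the series" means these compounds.

In a functional assay on K-562R cells (Homo sapiens) for cytotoxicity, read by MTT assay, with a stated time of 48 h (a higher number here means a weaker inhibitor, a lower number a stronger inhibitor), the measured compounds read as follows:
- compound 1 `COc1ccc(-c2c[nH]c(=O)n2-c2cc(OC)c(OC)c(OC)c2)cc1` gives > 50000 nM (a limit)
- compound 2 `COc1ccc(-c2cn(C(=O)Nc3cc(OC)c(OC)c(OC)c3)c(=O)n2-c2cc(OC)c(OC)c(OC)c2)cc1OC` gives > 50000 nM (a limit)
- compound 3 `COc1cc(-n2c(-c3ccc(Br)cc3)cn(C(C)=O)c2=O)cc(OC)c1OC` gives 900 nM (a number)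

Among the measured compounds shown here, compound 3 stands alone on these figures: its 900 nM is the only true number. The entries for the other two compounds are limits. It carries a 4-bromophenyl group and an acetyl group on the shared core.

Compound 4 `COc1ccc(-c2cn(C(C)=O)c(=O)n2-c2cc(OC)c(OC)c(OC)c2)cc1OC` keeps the acetyl group but has 3,4-dimethoxyphenyl in place of 4-bromophenyl on an aromatic carbon of the five-membered ring, two ring bonds from the ring atom bearing the acetyl group (3,4-dimethoxyphenyl in place of 4-bromophenyl on an aromatic carbon). For the measured compounds named here, no measured pair isolates this change, so the expectation rests on thin ground.

Compound 2 also carries 3,4-dimethoxyphenyl, though no acetyl group, and its > 50000 nM is a limit. That reading leans the expectation toward weaker inhibition. The expected change is a 3.3-fold higher number from compound 3 to compound 4 (0.52 log units; beyond the scatter) in this assay and would be a moderate weakening.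

Compound 4 is expected at 3000 nM in this assay, with an estimated range of 500 nM to 25000 nM around it.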

Compound 4, half-maximal inhibitory concentration: > 50000 nM
Compound 4: a limit, no number; the forecaster's own chance of this, stated with the estimate: 15%; middle value at least 16-fold (1.22 log units) from the limit.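

In this assay, among the compounds shown here, the exchange of 4-bromophenyl for 3,4-dimethoxyphenyl, with the acetyl group kept, gives an at least 55-fold higher number from compound 3 to compound 4 (1.74 log units; beyond the scatter) as the first step in this set that isolates a change at this aromatic carbon. The result shows that the acetyl group alone does not secure a measurable value on the shared core, since the value is lost once 3,4-dimethoxyphenyl enters at this position. From the compounds shown here alone, compound 4 gives > 50000 nM which is a limit, so the step sets only a lower bound on the change and its true size stays unknown: the limit of > 50000 nM in this assay, at which 3 of the 4 values shown sit.

The compounds shown leave open whether the loss of 4-bromophenyl or the entry of the two methoxy groups matters more, as a single methoxy on the phenyl ring appears only in compound 1, which lacks the acetyl group. They also leave open how 4-chlorophenyl or unsubstituted phenyl would read at this position, and whether a propionyl group could stand in place of the acetyl group alongside 4-bromophenyl.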